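The source may hold more compounds than are shown below. What is called first, only, known or untested is meant among the compounds shown, and "the series" means these compounds.

Measured so far:
- compound 1, `CC1=CC[C@@H]([C@@](C)(O)CCCC(C)(C)NC(=S)NN)CC1` — in a functional assay on UACC-62 cells (Homo sapiens) for cytotoxicity, read by sulforhodamine B assay (a lower number here means that less compound is tolerated, a higher number that more compound is tolerated), compound 1 gives > 100000 nM
- compound 2, `CC1=CC[C@@H]([C@@](C)(O)CCCC(C)(C)NC(=S)N/N=C\c2ccc(C)cc2)CC1` — in this assay compound 2 gives 52300 nM

The value given for compound 1 is a limit of the assay, not a number. Among the measured compounds shown here, compound 2 therefore holds the only real number in this assay, at the limit of > 100000 nM in this assay, at which 1 of the 2 values shown sits, the other entry sits. For the measured compounds named here, the one measured step, an at least 1.9-fold lower number from compound 1 to compound 2 (0.28 log units; that floor lies within the scatter), exchanges a large group for a single nitrogen on the amide-type nitrogen and still reaches only a floor that lies within the scatter.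

Compound 3, `COc1ccc(/C=N\NC(=S)NC(C)(C)CCC[C@](C)(O)[C@@H]2CC=C(C)CC2)cc1`, differs from compound 2 by methoxy in place of methyl on an aromatic carbon. Going by the values given here, this change sits on the aromatic ring, far from where the measured step took place, and no measured pair shows what methoxy in place of methyl does here. The measured step gives no reason to expect movement, so compound 3 is expected to show a 1.0-fold lower number from compound 2 to compound 3 (0.02 log units; within the scatter). The estimate for compound 3 in this assay is 50000 nM, within 20000 nM to 130000 nM.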

Compound 3, concentration lethal to 50% of the cells: 48500 nM
Compound 3: the middle estimate sits 1.0-fold (0.01 log units) above what was measured; low and high end bracket the measured number.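

On the aromatic ring, methoxy in place of methyl gives a 1.1-fold lower number from compound 2 to compound 3 (0.03 log units; within the scatter), so in this assay this exchange at the position para to a large group does not separate the two compounds. Adding the aromatic group to the end of compound 1 now gives a step that clears the scatter: an at least 2.0-fold lower number from compound 1 to compound 3 (0.31 log units; beyond the scatter). The value for compound 1 is a limit and not a number, so that step is only a floor: the limit of > 100000 nM in this assay, at which 1 of the 3 values shown sits.

From the compounds shown here alone, it remains open whether a different group at this ring position, such as an amine or a carboxylic acid, would shift the number beyond the scatter. Also open, going by these compounds, is how large the true step from compound 1 is, since only its floor can be read.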